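The compounds below may be only part of what the source reports. "The series", "measured", "known", "first", "only" and "open" are said of these compounds alone.

In a functional assay on cells (Pituitary gland cell) for antagonist activity at Gonadotropin-releasing hormone receptor (Rattus norvegicus) (on this read-out lower numbers stand for stronger inhibition and higher numbers for weaker inhibition), compound 3 `O=[N+]([O-])c1cc2c(OCCC3CCCCN3)c(-c3cccc(F)c3)c(O)nc2cc1Cl` gives 53 nM, the second highest of three numbers. Its nearest neighbour is compound 2 `CC(=O)OCc1cc(C)cc(-c2c(O)nc3cc(Cl)c([N+](=O)[O-])cc3c2OCCC2CCCCN2)c1`, which gives 45 nM; the step of a 1.2-fold higher number from compound 2 to compound 3 (0.07 log units; within the scatter) lies within the scatter. The furthest is compound 1 `COc1ccc(-c2c(O)nc3cc(Cl)c([N+](=O)[O-])cc3c2OCCC2CCCCN2)cc1OC`, which gives 600 nM; here an 11-fold lower number from compound 1 to compound 3 (1.05 log units; beyond the scatter) lies beyond the scatter. Compound 4 `O=[N+]([O-])c1cccc(-c2c(O)nc3cc(Cl)c([N+](=O)[O-])cc3c2OCCC2CCCCN2)c1` differs from compound 3 by nitro in place of fluoro on an aromatic carbon. Among the measured compounds shown here, two measured steps concern changes on the phenyl group: an 11-fold lower number from compound 1 to compound 3 (1.05 log units; beyond the scatter) was large, whereas a 1.2-fold higher number from compound 2 to compound 3 (0.07 log units; within the scatter) stayed within the scatter, so such changes range from large to negligible, and no measured step exchanges a single substituent for nitro. Compound 4 is therefore expected to show a 1.3-fold higher number from compound 3 to compound 4 (0.12 log units; within the scatter), within the scatter. In this assay compound 4 is estimated at 70 nM, between 20 nM and 250 nM.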

Compound 4, half-maximal inhibitory concentration: 100 nM
Estimate against measurement, compound 4: 1.4-fold (0.15 log units) below; measured number inside the range.
By their numbers in this assay, from the lowest: compounds 2, 3 and 4 (each within the scatter of the next, the first and the last beyond it); then compound 1.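

In this assay, among the compounds shown here, the one exchange of a single substituent on this phenyl group, nitro in place of fluoro, gives a 1.9-fold higher number from compound 3 to compound 4 (0.28 log units; within the scatter), so the two groups are not told apart at this position. The 3-nitrophenyl group nevertheless falls just beyond the scatter against 3-(acetoxymethyl)-5-methylphenyl, with a 2.2-fold higher number from compound 2 to compound 4 (0.35 log units; beyond the scatter), and it remains clearly better than 3,4-dimethoxyphenyl, with a 6.0-fold lower number from compound 1 to compound 4 (0.78 log units; beyond the scatter). No evidence at hand accounts for these steps. From the compounds shown here alone, whether an amine or a carboxylic acid on this carbon would match the numbers of compound 3 and compound 4 stays open.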